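This account rests on a few compounds, and the source may have more. Where it says the series, first, only, none or still open, it means among the compounds named here.

In a functional assay on MCF7 cells (Homo sapiens) for cytotoxicity, read by MTT assay, with a stated time of 72 h, tested at 100 uM (on this read-out higher numbers stand for more inhibition of growth at the one concentration tested and lower numbers for less inhibition of growth), compound 3 `N/C(=N\NC(=S)N1CCCCC1)c1ccccn1` gives 77.7%, the highest of the three numbers, though only just. Compound 2 `Cc1ccnc(/C(N)=N/NC(=S)N2CCSCC2)c1` gives 76.8%, which lies within the scatter of compound 3, so the two cannot be set apart. Going by the values given here, compound 1 `Cc1ccnc(/C(N)=N/NC(=S)N2CCOCC2)c1` gives 12.8%, and the single measured step, a number 64 percentage points higher from compound 1 to compound 2 (beyond the scatter), is large. Compound 4 `Cc1ccnc(/C(N)=N/NC(=S)N2CCCCC2)c1` differs from compound 3 by methyl in place of hydrogen on an aromatic carbon. Among the compounds with values here, no measured step touches this part of the structure; the one large step concerns a different group, and compound 2 and compound 3, which differ in more than one place including the methyl, sit together. The change is therefore expected to bring no step beyond the scatter, a number 2.7 percentage points lower from compound 3 to compound 4 (within the scatter). Compound 4 is estimated at 75%, between 55% and 90%.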

Compound 4, percent growth inhibition at one concentration: 80.1%
The estimate for compound 4 lay 5.1 percentage points below the measured number; the measured number falls inside the stated range.
By their numbers in this assay, from the lowest: compound 1; then compounds 2, 3 and 4 (each within the scatter of the next).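

In this assay, methyl in place of hydrogen on the aromatic carbon opposite the ring nitrogen is tolerated alongside piperidin-1-yl, with a number 2.4 percentage points higher from compound 3 to compound 4 (within the scatter). With that methyl present in all three compounds, piperidin-1-yl and thiomorpholin-4-yl cannot be set apart, with a number 3.3 percentage points higher from compound 2 to compound 4 (within the scatter), while replacing morpholin-4-yl gives a number 67.3 percentage points higher from compound 1 to compound 4 (beyond the scatter), so the morpholin-4-yl compound alone stands apart. No available evidence explains this difference. Still open, going by these compounds, is whether an amine, a carboxylic acid or a longer chain at that aromatic carbon would be tolerated equally.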